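The compounds below may be only part of what the source reports. "The series", "measured", "known", "first", "only" and "open" are said of these compounds alone.

The compounds measured so far in an ADME assay on microsomes from liver (Mus musculus) for metabolic stability; on this read-out lower numbers stand for a shorter-lived compound and higher numbers for a longer-lived compound:

compound 1, `CC(C)C(c1nnc[nH]1)c1ccc(-c2ccc3cccc(F)c3c2)[nH]c1=O`, 0.213 h
compound 2, `CC(C)C(Cc1ncc[nH]1)c1ccc(-c2ccc3cccc(F)c3c2)[nH]c1=O`, < 0.0667 h
compound 3, `CC(C)C(Cc1nnn[nH]1)c1ccc(-c2ccc3cccc(F)c3c2)[nH]c1=O`, 0.853 h

Compound 2 stands at the bottom of the three. Its value in this assay is a limit of the assay rather than a number, and it is the only one of the three at the limit of < 0.0667 h in this assay, at which 1 of the 3 values shown sits. The two measured steps that touch it are both beyond the scatter: an at least 3.1-fold lower number from compound 1 to compound 2 (0.50 log units; beyond the scatter), and an at least 12-fold higher number from compound 2 to compound 3 (1.10 log units; beyond the scatter). Among the measured compounds shown here, the third step, a 4.0-fold higher number from compound 1 to compound 3 (0.60 log units; beyond the scatter), shows that the compound with the tetrazolyl group sits above the one with the triazolyl group by a modest margin.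

The new compound is compound 4, `CC(C)C(Nc1nnc[nH]1)c1ccc(-c2ccc3cccc(F)c3c2)[nH]c1=O`. It differs from compound 2 in one place: (4H-1,2,4-triazol-3-yl)amino in place of (1H-imidazol-2-yl)methyl on a saturated chain carbon bound to an aromatic carbon and a saturated chain carbon. For the measured compounds named here, the group that leaves is the same one whose presence goes with the shortest half-life seen here, and the ring that enters is the one carried by compound 1, which was measured as a number rather than a limit. On that basis a step upward beyond the scatter is expected, an at least 4.4-fold higher number from compound 2 to compound 4 (0.65 log units; beyond the scatter). The half-life of compound 4 in this assay is therefore estimated at 0.3 h, with a likely range from 0.1 h to 0.9 h.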

Compound 4, half-life: 2.42 h
Compound 4: middle estimate off by 8.1-fold (0.91 log units), on the low side; the measured number lies above the stated range.
By their numbers in this assay, from the lowest: compound 1; then compound 3; then compound 4. At a limit, below all of these: compound 2.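

Keeping the triazolyl ring and adding only an amino link on the saturated chain carbon gives, in this assay, an 11-fold higher number from compound 1 to compound 4 (1.06 log units; beyond the scatter), so this link matters a great deal at this position, which the earlier compounds could not show. The amino-linked triazolyl group also goes past the methyl-linked tetrazolyl group, with a 2.8-fold higher number from compound 3 to compound 4 (0.45 log units; beyond the scatter), which makes compound 4 the longest-lived of the four and shows that the rise seen with the tetrazolyl group was not the ceiling here. The gap to the imidazolyl compound is an at least 36-fold higher number from compound 2 to compound 4 (1.55 log units; beyond the scatter), and it starts from a value that is a limit of the assay, not a number: the limit of < 0.0667 h in this assay, at which 1 of the 4 values shown sits.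

What the compounds shown leave open is whether the amino link helps whichever ring it carries, since (1H-imidazol-2-yl)amino and (1H-tetrazol-5-yl)amino groups on the same carbon would separate the effect of the link from that of the ring. From the compounds shown here alone, it is equally open whether the hydrogen on the link nitrogen matters, which a methylated amine or an ether oxygen in its place would address.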